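Chloro Removal in a Small Cytotoxicity Series

The source may hold more compounds than are shown below. What is called first, only, known or untested is meant among the compounds shown, and "the series" means these compounds.

Compound 1 `O=C(c1cccnc1)c1cc(Cl)cc(Cl)c1O`: 29600 nM
Compound 2 `O=C(c1cccnc1)c1cc(Cl)ccc1O`: 29000 nM
Compound 3 `C=CCOc1ccc(Cl)cc1C(=O)c1cccnc1`: 54000 nM

All three compounds were tested in a functional assay on MCF7 cells (Homo sapiens) for cytotoxicity, read by sulforhodamine B assay, with a stated time of 48 h (on this read-out higher numbers stand for weaker inhibition and lower numbers for stronger inhibition), and their three numbers lie within the usual scatter of one another. One structural change is already recorded: hydrogen in place of chloro on an aromatic carbon gave a 1.0-fold lower number from compound 1 to compound 2 (0.01 log units; within the scatter). Compound 4 `C=CCOc1ccccc1C(=O)c1cccnc1` has not yet been measured; it arises from compound 3 by the same kind of change, (hydrogen in place of chloro on an aromatic carbon). The surroundings differ, though: in compound 1 the leaving chloro sits ortho to a hydroxy group and meta to a chloro group, whereas in compound 3 it sits para to an allyloxy group. The difference between the two cores is not broken down here. Resting on a 1.0-fold lower number from compound 1 to compound 2 (0.01 log units; within the scatter), compound 4 is expected to show a 1.0-fold lower number from compound 3 to compound 4 (0.02 log units; within the scatter). The estimate for compound 4 in this assay is 52000 nM, expected between 25000 nM and 110000 nM.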

Compound 4, half-maximal inhibitory concentration: > 100000 nM
Compound 4 gave a limit, no number; the forecaster's own chance of this, stated with the estimate: 20%; middle value at least 1.9-fold (0.28 log units) from the limit.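

In this assay compound 4 gave > 100000 nM, which is a limit of the assay and not a number. Hydrogen in place of chloro on the core of compound 3 therefore gave only a floor for the step: an at least 1.8-fold higher number from compound 3 to compound 4 (0.26 log units; that floor lies within the scatter). Set beside the earlier step, this neither shows that the change carries over from one core to the other nor shows that it fails to: the same change on two cores in this assay, a 1.0-fold lower number (0.01 log units; within the scatter) from compound 1 to compound 2 and an at least 1.8-fold higher number (0.26 log units; that floor lies within the scatter) from compound 3 to compound 4; the limit leaves it open whether they differ

The compounds shown leave open what a bromo or a methoxy group in place of the chloro would give on either core. They also leave open whether a longer chain in place of the allyl group would alter the step.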